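The source may hold more compounds than are shown below. What is called first, only, known or untested is meant among the compounds shown, and "the series" means these compounds.

Three compounds share one core, and in a functional assay with Homo sapiens as the target (a lower number here means a stronger inhibitor, a higher number a weaker inhibitor), they spread over a wide range. Compound 1 `Cc1c(C(=O)Nc2cccc(C(F)(F)F)c2)cnn1-c1ccc(F)cc1` gives 1700 nM. Compound 2 `COc1ccc(-n2ncc(C(=O)Nc3ccc(C(F)(F)F)cc3)c2C)cc1` gives 340 nM and compound 3 `Cc1c(C(=O)Nc2ccc(C(F)(F)F)cc2)cnn1-c1ccc([N+](=O)[O-])cc1` gives 5700 nM. Compound 3 therefore stands highest of the three numbers in this assay, with compound 1 nearest below it and compound 2 furthest below it. For the measured compounds named here, the one measured step that reaches compound 3 is a 17-fold higher number from compound 2 to compound 3 (1.22 log units; beyond the scatter). Compound 4 `COc1cccc(-n2ncc(C(=O)Nc3ccc(C(F)(F)F)cc3)c2C)c1` is not yet measured; it differs from compound 3 by 3-methoxyphenyl in place of 4-nitrophenyl on an aromatic nitrogen. Going by the values given here, this change largely undoes the earlier one, since a methoxy group returns in place of nitro, although compound 4 carries a 3-methoxyphenyl and compound 2 carries its methoxy elsewhere on that ring, and no measured pair shows what moving the methoxy alone does. Because a 17-fold higher number from compound 2 to compound 3 (1.22 log units; beyond the scatter) was large, a large step in the opposite direction is expected here, though perhaps not the whole way back. The estimate for compound 4 in this assay is 600 nM, with a range from 200 nM to 2000 nM. That expected number means a 9.5-fold lower number from compound 3 to compound 4 (0.98 log units; beyond the scatter).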

Compound 4, half-maximal inhibitory concentration: 2500 nM
Estimate against measurement, compound 4: 4.2-fold (0.62 log units) below, outside the stated range (above it).
By their numbers in this assay, from the lowest: compound 2; then compounds 1 and 4 (each within the scatter of the next); then compound 3.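

For the compounds shown here, compound 2 and compound 4 form the first measured pair that isolates where the methoxy sits on the ring carried by the aromatic nitrogen: in this assay, 3-methoxyphenyl in place of 4-methoxyphenyl gives a 7.4-fold higher number from compound 2 to compound 4 (0.87 log units; beyond the scatter) and so is not a neutral move. Replacing 4-nitrophenyl with 3-methoxyphenyl gives only a 2.3-fold lower number from compound 3 to compound 4 (0.36 log units; beyond the scatter) against the earlier 17-fold higher number from compound 2 to compound 3 (1.22 log units; beyond the scatter) for nitro in place of methoxy, so among these compounds, having a methoxy on this ring does not by itself bring the number back to that of compound 2. Nothing available explains either step.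

Going by these compounds, what remains open is how an amine or a carboxylic acid on this ring would compare with the methoxy. On these data alone, it is also open whether the cost of moving the methoxy would hold with a different group on the amide side of the core.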